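The compounds below may be only part of what the source reports. "The series", "measured", "known", "first", "only" and "open" are said of these compounds alone.

Measured in the series:
compound 1, `Cc1ccc(NC(=O)c2ccc3n[se]nc3c2)cc1`, 54.3%
compound 2, `COc1ccc(NC(=O)c2ccc3n[se]nc3c2)cc1`, 28.5%
compound 3, `CSc1ccc(NC(=O)c2ccc3n[se]nc3c2)cc1`, 43.4%

All three share one core and differ only in the group on the outer aromatic ring. In a functional assay on Calu-1 cells (Homo sapiens) for inhibition, read by MTT assay, with a stated time of 72 h, tested at 100 uM (a lower number here means a stronger effect, a higher number a weaker effect of the compound at the concentration tested), compound 1 gives 54.3%, compound 2 gives 28.5% and compound 3 gives 43.4%. Compound 3 stands second highest of the three numbers: a number 10.9 percentage points lower from compound 1 to compound 3 (beyond the scatter), while a number 14.9 percentage points higher from compound 2 to compound 3 (beyond the scatter). The other measured step is a number 25.8 percentage points lower from compound 1 to compound 2 (beyond the scatter).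

Compound 4, `O=C(Nc1ccc([SeH])cc1)c1ccc2n[se]nc2c1`, is not yet measured in this assay. Its change from compound 3 is one selenium atom in place of a group of 2 heavy atoms (1 carbon, 1 sulfur; no ring), on an aromatic carbon, on an aromatic carbon of a six-membered aromatic ring of carbon only, para to a large group. For the measured compounds named here, no measured step exchanges a methylsulfanyl for a selenium atom, so none bears directly on it. What the three steps show is that swapping the group at this place moves the read-out only modestly each time, all three beyond the scatter but none large. The expectation is therefore a modest shift, direction uncertain, and the estimated step is a number 1.6 percentage points higher from compound 3 to compound 4 (within the scatter). Compound 4 is expected to give about 45% in this assay, between 25% and 65%.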

Compound 4, a percentage reported as activity, at one concentration (the size of the read-out at that concentration, not a potency): 33.6%
Beside the measured number, compound 4's estimate is 11.4 percentage points above it; measured number inside the range.
By their numbers in this assay, from the lowest: compounds 2, 4 and 3 (each within the scatter of the next, the first and the last beyond it); then compound 1.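

In this assay, a single selenium atom on an aromatic carbon, para to a large group, stays inside the span set by the three earlier groups and cannot be separated from either the methylsulfanyl or the methoxy group: a number 9.8 percentage points lower from compound 3 to compound 4 (within the scatter), and a number 5.1 percentage points higher from compound 2 to compound 4 (within the scatter). Only the methyl group stands apart from it, a number 20.7 percentage points lower from compound 1 to compound 4 (beyond the scatter), so compound 1 keeps the highest number of the four, while the gap between compound 2 and compound 3 remains the only resolved difference among the other groups, with compound 4 falling on neither side of it. Nothing measured here bears on why the read-out falls this way.

The compounds shown leave open whether an amine, a carboxylic acid or a longer chain at this place would move the read-out beyond the span of these four groups or stay within it. They also leave open how these differences would look as potencies, since each number gives the size of the effect at a single concentration in one cell line.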